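A few compounds are considered here, and "the series" means these few. Any claim that something is new, unique, unknown or untested is made for them only; others in the source may bear on it.

Measured compounds:

compound 1 `O=C(Nc1cccc([N+](=O)[O-])c1)N1CCN(S(=O)(=O)c2sccc2-c2ccccc2Oc2ccc(O)c(O)c2)CC1` — > 20000 nM in an ADME assay on HEK-293T cells (Homo sapiens) for cytotoxicity, read by CCK-8 assay, with a stated time of 48 h; a lower number here means a stronger inhibitor, a higher number a weaker inhibitor
compound 2 `O=[N+]([O-])c1ccc(NC(=S)N2CCN(S(=O)(=O)c3sccc3-c3ccccc3Oc3ccc(O)c(O)c3)CC2)cc1` — > 20000 nM
compound 3 `Cc1ccc(-c2ccsc2S(=O)(=O)NCCNC(=S)Nc2cc(C(F)(F)F)cc(C(F)(F)F)c2)c(Oc2ccc(O)c(O)c2)c1` — 8000 nM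

Compound 2 stands at the limit of > 20000 nM in this assay, at which 2 of the 3 values shown sit, which is a limit of the assay and not a measured number. Compound 1 stands at the same limit, so the step that the two limits leave unreadable from compound 1 to compound 2 cannot be read. Among the compounds with values here, compound 3 is the only one of the three that gives a number, but it differs from compound 2 in more than one place, so no single step links them.

Compound 4 `COc1ccc(Oc2ccccc2-c2ccsc2S(=O)(=O)N2CCN(C(=S)Nc3ccc([N+](=O)[O-])cc3)CC2)cc1OC` differs from compound 2 in one place: 3,4-dimethoxyphenyl in place of 3,4-dihydroxyphenyl on an oxygen on an aromatic ring. Within the data shown here, none of the measured steps involves this change, so there is nothing to set its size from; the one step that was measured, from compound 1 to compound 2, is itself unreadable. The expectation therefore rests only on where compound 2 stands. For compound 4 the estimated step that the limit leaves unreadable from compound 2 to compound 4 is taken to be none beyond the scatter. Compound 4 is therefore expected to give about 25000 nM in this assay, with a range of 10000 nM to 60000 nM, and most likely to be reported as a limit again.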

Compound 4, half-maximal inhibitory concentration: > 20000 nM
Compound 4: a limit, no number; the forecaster's own chance of this, stated with the estimate: 70%; the middle value is on the limit's open side.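

Compound 2 and compound 4 both stand at a limit of the assay and give no number, so the swap of 3,4-dihydroxyphenyl for 3,4-dimethoxyphenyl cannot be sized: the limit of > 20000 nM in this assay, at which 3 of the 4 values shown sit.

The compounds shown leave open whether this swap changes the result in this assay at all, and in which direction.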